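Methyl-to-chloro exchange in a small lipophilicity series

The source may report more compounds than this note shows. Statements on the series, on what has been measured and on what is new or still open speak of the compounds shown alone.

Measured compounds:
compound 1, `Cc1cccc2c1c([N+](=O)[O-])cc[n+]2[O-]`, 1.25
compound 2, `Cc1ccc2c(c1)c([N+](=O)[O-])cc[n+]2[O-]`, 1.24
compound 3, `O=[N+]([O-])c1cc[n+]([O-])c2ccc(Cl)cc12`, 1.4

In a physicochemical assay for lipophilicity (a lower number here means a more polar compound, a higher number a more lipophilic compound), compound 1 gives 1.25 and compound 2 gives 1.24; the two have the same atoms joined differently, and the difference between the two cores is not broken down here. The step of a number 0.16 log units higher from compound 2 to compound 3 (within the scatter) follows the change (chloro in place of methyl on an aromatic carbon).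

Compound 4, `O=[N+]([O-])c1cc[n+]([O-])c2cccc(Cl)c12`, is not yet measured in this assay. It differs from compound 1 by chloro in place of methyl on an aromatic carbon, the same kind of change as that from compound 2 to compound 3, though not the same: in one case the place is ortho to a fused ring and meta to a fused ring, in the other meta to a fused ring and para to a fused ring. Because a number 0.16 log units higher from compound 2 to compound 3 (within the scatter) was small, a step of similar size, a number 0.16 log units higher from compound 1 to compound 4 (within the scatter), is expected. Compound 4 is therefore estimated at 1.41, between 1.2 and 1.65.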

Compound 4, partition coefficient: 1.75
For compound 4 the middle estimate is 0.34 log units below the measured one; the whole stated range lies below it.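

In this assay chloro in place of methyl gives a number 0.50 log units higher from compound 1 to compound 4 (beyond the scatter) on the core of compound 1, against a number 0.16 log units higher from compound 2 to compound 3 (within the scatter) on the other core, so the size of the step did not carry from one core to the other. With a single pair on each core, this does not show how the same exchange would behave on any further core, and it gives no general rule for either place on the ring. No measurement here bears on the reason for the difference between the two steps.

Still open, going by these compounds, is how an amine, a carboxylic acid or a longer chain would behave on this same aromatic carbon. Whether such groups would show the same dependence on the core also remains unanswered.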